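The source may report more compounds than this note shows. Statements on the series, on what has been measured and on what is new or still open speak of the compounds shown alone.

In an assay on lysate for inhibition of phosphatidylcholine:ceramide cholinephosphotransferase 2 (Homo sapiens), read by HPLC, with stated times of 30 min and 2 h (a lower number here means a stronger inhibitor, a higher number a weaker inhibitor), compound 1 `O=C(Nc1cccnc1)c1ccccc1OCc1ccccc1` gives 3200 nM, compound 2 `O=C(Nc1cccnc1)c1ccccc1OCc1ccccc1F` gives 3500 nM, and compound 3 `Cc1ccc(Cl)cc1COc1ccccc1C(=O)Nc1cccnc1` gives 1100 nM.

Compound 3 stands lowest of the three: the steps of a 2.9-fold lower number from compound 1 to compound 3 (0.46 log units; beyond the scatter) and a 3.2-fold lower number from compound 2 to compound 3 (0.50 log units; beyond the scatter) both lie beyond the scatter, whereas a 1.1-fold higher number from compound 1 to compound 2 (0.04 log units; within the scatter) lies within it. Compound 4 `COCCCOc1ccc(Cl)cc1COc1ccccc1C(=O)Nc1cccnc1` differs from compound 3 by 3-methoxypropoxy in place of methyl on an aromatic carbon. For the measured compounds named here, no measured step touches that methyl; the two steps that reach beyond the scatter exchange the whole ring on the chain carbon bound to the oxygen, and none of the three adds a chain on an aromatic carbon. The record therefore gives no ground for a step beyond the scatter in this assay in either direction. Compound 4 is accordingly expected to give about 1000 nM, between 300 nM and 4000 nM. That estimate means a step of a 1.1-fold lower number from compound 3 to compound 4 (0.04 log units; within the scatter), which is expected to stay within the scatter.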

Compound 4, half-maximal inhibitory concentration: 4100 nM
Compound 4: middle estimate off by 4.1-fold (0.61 log units), on the low side; measured number above the stated range.
By their numbers in this assay, from the lowest: compound 3; then compounds 1, 2 and 4 (each within the scatter of the next).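

In this assay, the aromatic carbon ortho to a large group and para to a chloro group proves sensitive to change: 3-methoxypropoxy in place of methyl gives a 3.7-fold higher number from compound 3 to compound 4 (0.57 log units; beyond the scatter) and so costs inhibition. The earlier steps shown here only exchanged the whole ring or placed a fluoro on it, and none isolated this position. Nothing measured here bears on why the number rises.

Going by these compounds, whether a shorter methoxy group or a chain ending in an amine would hold the level of compound 3 remains open. The compounds shown also do not separate the length of the chain from its oxygens, as a plain butyl chain could.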